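The source may report more compounds than this note shows. Statements on the series, on what has been measured and on what is new or still open speak of the compounds shown alone.

Compound 1 `O=C(Nc1cccc(-n2cc(-c3ccncc3)c(-c3cc(O)cc(Cl)c3)n2)c1)Nc1ccc(Cl)c(Cl)c1` carries a hydroxy group on its aryl ring, and in a functional assay on Malme-3M cells (Homo sapiens) for inhibition, read by sulforhodamine B assay, with a stated time of 48 h, tested at 0.01 uM (on this read-out lower numbers stand for a stronger effect and higher numbers for a weaker effect at the one concentration tested), compound 1 gives 57%, the lowest of the three numbers recorded, and so the strongest effect seen at the single concentration tested. Compound 2 `COc1cc(Cl)cc(-c2nn(-c3cccc(NC(=O)Nc4ccc(Cl)c(C(F)(F)F)c4)c3)cc2-c2ccncc2)c1` gives 94% in this assay, and compound 3 `COc1cc(Cl)cc(-c2nn(-c3cccc(NC(=O)Nc4cc(C(F)(F)F)cc(C(F)(F)F)c4)c3)cc2-c2ccncc2)c1` gives 92%; both numbers stand beyond the scatter above that of compound 1. Among the compounds with values here, compound 2 and compound 3 each carry a methoxy group where compound 1 has hydroxy, but they also differ from compound 1 elsewhere in the molecule, so no single step between measured compounds connects them to it.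

Compound 4 `COc1cc(Cl)cc(-c2nn(-c3cccc(NC(=O)Nc4ccc(Cl)c(Cl)c4)c3)cc2-c2ccncc2)c1` differs from compound 1 in one place only: methyl in place of hydrogen on an oxygen on an aromatic ring. Within the data shown here, with no measured step of this kind available, the expectation rests on what the other two numbers show. Because compound 2 gives 94% and compound 3 gives 92%, both with the methoxy group, compound 4 is expected to move towards a weaker effect. The step from compound 1 to compound 4 is estimated at a number 27 percentage points higher from compound 1 to compound 4 (beyond the scatter), a rise beyond the scatter. Compound 4 is therefore expected to give about 84% in this assay, within a range of 64% to 98%.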

Compound 4, a percentage reported as activity, at one concentration (the size of the read-out at that concentration, not a potency): 92%
For compound 4 the middle estimate is 8 percentage points below the measured one; the range from low to high includes it.
By their numbers in this assay, from the lowest: compound 1; then compounds 3, 4 and 2 (each within the scatter of the next).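

Within the data shown here, replacing 3-chloro-5-hydroxyphenyl with 3-chloro-5-methoxyphenyl gives the first direct reading of this position: in this assay, methyl in place of hydrogen on an oxygen on an aromatic ring produces a large step, a number 35 percentage points higher from compound 1 to compound 4 (beyond the scatter), and so a clear loss of effect at the one concentration tested. With the methoxy group kept, chloro in place of trifluoromethyl on an aromatic carbon gives a number 2 percentage points lower from compound 2 to compound 4 (within the scatter), so compound 2 and compound 4 cannot be told apart in this assay, and that exchange does not separate this pair as the hydroxy to methoxy change separates compound 1 from compound 4. The data shown offer no measurement that explains the step at the oxygen.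

It remains open whether the same hydroxy to methoxy step would appear with the other substitution patterns of compound 2 and compound 3, whose hydroxy counterparts are not among the compounds shown. Going by these compounds, how an ethoxy group, a longer chain, an amine or a carboxylic acid would read at this place also remains unknown, as does the size of any of these steps at other concentrations.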